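The source may report more compounds than this note shows. Statements on the series, on what has been measured and on what is new or still open speak of the compounds shown alone.

Measured compounds and their values:
compound 1, `CCc1ccccc1-n1nc(C)c2c1NC(=O)[C@H](C)S[C@@H]2c1ccc(Oc2ccccc2)cc1`: 1100 nM
compound 2, `Cc1ccccc1-n1nc(C)c2c1NC(=O)[C@H](C)S[C@@H]2c1ccc(-c2cc3ccccc3o2)cc1`: 1500 nM

In an assay on isolated protein for agonist activity at Bile acid receptor (Homo sapiens), read by AlphaScreen, with a stated time of 30 min (a lower number here means that less compound is needed, a higher number that more compound is needed for the effect), compound 2 gives 1500 nM, the highest of the two numbers shown, while compound 1 gives 1100 nM, a value that lies within the usual scatter of it. Compound 3, `Cc1ccccc1-n1nc(C)c2c1NC(=O)[C@H](C)S[C@@H]2c1ccc(/C=C/c2ccccc2)cc1`, differs from compound 2 at one place: 2-phenylethenyl in place of 1-benzofuran-2-yl on an aromatic carbon. For the measured compounds named here, no step between two measured compounds matches this change, so the expectation rests on compound 2 alone. The step of a 1.2-fold lower number from compound 2 to compound 3 (0.06 log units; within the scatter) is expected to be none beyond the scatter. Compound 3 is therefore estimated at 1300 nM, with a range from 400 nM to 4000 nM.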

Compound 3, half-maximal effective concentration: "not active" (no number reported)
Compound 3: no number reported; there is nothing to compare the estimate with.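

In this assay, for the compounds shown here, compound 3 is reported as not active, without a number, so no step from compound 2 to compound 3 can be read. Nothing shown explains this result. The compounds shown leave open how far compound 3 lies from compound 2.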